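Working notes: methyl-for-hydrogen steps in lipophilicity

The source may report more compounds than this note shows. Statements on the series, on what has been measured and on what is new or still open speak of the compounds shown alone.

Measured in a physicochemical assay for lipophilicity; a lower number here means a more polar compound, a higher number a more lipophilic compound:
- compound 1 `CC(/C=C/CC(C)CCCC(C)C)=C\C(=O)OC(C)C` gives 7.15
- compound 2 `CC(/C=C/CC(C)CCCC(C)(C)C)=C\C(=O)OC(C)C` gives 7.56
- compound 3 `CCNC(=O)/C=C(C)/C=C/CC(C)CCCC(C)(C)OC` gives 4.04

Compound 3 stands lowest of the three, with its gaps to compound 1 and compound 2 both beyond the scatter. The difference between the core of compound 3 and the core of compound 1 is not broken down here.

Between compound 1 and compound 2 the change is methyl in place of hydrogen on a saturated chain carbon bound to three saturated chain carbons, and it brings a number 0.41 log units higher from compound 1 to compound 2 (beyond the scatter).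

Compound 4 `COC(C)(C)CCCC(C)C/C=C/C(C)=C/C(=O)NC(C)C` is not yet measured in this assay. It differs from compound 3 by methyl in place of hydrogen on a saturated chain carbon bound to an amide-type nitrogen and a saturated chain carbon. This is the same kind of change as that from compound 1 to compound 2, but not the same: there the methyl enters on a saturated chain carbon bound to three saturated chain carbons, here on a saturated chain carbon bound to an amide-type nitrogen and a saturated chain carbon.

The expectation for compound 4 rests on the step seen between compound 1 and compound 2, a number 0.41 log units higher from compound 1 to compound 2 (beyond the scatter), and a step of about the same size is expected, a number 0.41 log units higher from compound 3 to compound 4 (beyond the scatter). For compound 4 in this assay the estimate is 4.45, expected between 4.15 and 4.75.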

Compound 4, partition coefficient: 4.45
Compound 4: the middle estimate sits on the measured number at the digits printed; measured number inside the range.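

In this assay methyl in place of hydrogen brings a number 0.41 log units higher from compound 3 to compound 4 (beyond the scatter) on a saturated chain carbon bound to an amide-type nitrogen and a saturated chain carbon, and a number 0.41 log units higher from compound 1 to compound 2 (beyond the scatter) on a saturated chain carbon bound to three saturated chain carbons, so the two steps match at the digits printed. This is a single pair on each of two cores, and the pairs differ in the place of the methyl as well as in the core, so it shows agreement in these two cases only, gives no general rule for the series, and cannot separate an influence of the core from one of the place. Nothing available bears on why the two steps match in size.

The compounds shown leave open whether a step of this size would hold for a longer chain, such as propylcarbamoyl in place of ethylcarbamoyl. Also open, going by these compounds, is how the same change would read on a core carrying an amine or a carboxylic acid.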